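Dipropylamino in Place of a Carbamate on a Fused Core

The source may report more compounds than this note shows. Statements on the series, on what has been measured and on what is new or still open speak of the compounds shown alone.

Compound 1 `Cc1nc2c(CCc3ccccc3)cccn2c1N`: 47%
Compound 2 `COC(=O)Nc1c(C)nc2c(OCc3ccccc3)cccn12`: 0%

In a functional assay on the whole organism with Rattus norvegicus as the target, at a dose of 40 mg/kg by the intraperitoneal route (a lower number here means less inhibition, a higher number more inhibition at the dose given (going by the name of the read-out)), compound 1 gives 47%, while compound 2 gives 0%, the lowest of the two numbers and beyond the scatter below compound 1. Compound 3 `CCCN(CCC)c1c(C)nc2c(OCc3ccccc3)cccn12` has not been measured; it differs from compound 2 by dipropylamino in place of (methoxycarbonyl)amino on an aromatic carbon. Within the data shown here, no measured pair isolates this change, so its size is open. Compound 1 shows that numbers well above zero occur on this core. Compound 3 is expected to give a modest rise, a number 20 percentage points higher from compound 2 to compound 3 (beyond the scatter), in this assay. The estimate for compound 3 is 20%, between 0% and 55%.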

Compound 3, a percentage reported as inhibition, in the whole organism at one dose (the size of the read-out at that dose, not a potency): 60%
Beside the measured number, compound 3's estimate is 40 percentage points below it; measured number above the stated range.
By their numbers in this assay, from the lowest: compound 2; then compound 1; then compound 3.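

In this assay, dipropylamino in place of (methoxycarbonyl)amino on this aromatic carbon gives a number 60 percentage points higher from compound 2 to compound 3 (beyond the scatter) on an otherwise unchanged core, so this one position can carry a large difference in the read-out. The change also swaps a group with a hydrogen-bond donor for a larger one without any. No evidence here shows which of these differences matters, if either.

The compounds shown leave open how the read-out would respond to a free amine, dimethylamino or dibutylamino at this position. They also leave open whether an acetylamino group would behave like (methoxycarbonyl)amino.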